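A few compounds are considered here, and "the series" means these few. Any claim that something is new, unique, unknown or untested is made for them only; others in the source may bear on it.

Among the measured compounds shown here, in a functional assay on the whole organism (CCRF S-180 cells, Mus musculus) for inhibition, in a xenograft, with stated times of 7 days and 24 h, at a dose of 100 umol/kg by the intraperitoneal route (a higher number here means more inhibition at the dose given (going by the name of the read-out), a lower number less inhibition), compound 2 `NC(=O)CC[C@H](NC(=O)c1cc2ccccc2cn1)C(=O)OCc1ccccc1` gives 11.9%, the lower of the two numbers known so far; compound 1 `CC(C)[C@H](NC(=O)c1cc2ccccc2cn1)C(=O)OCc1ccccc1` gives 29.7%. The step of a number 17.8 percentage points lower from compound 1 to compound 2 (beyond the scatter) is the only one that bears on the new compound. Compound 3 `CC[C@@H](C)[C@H](NC(=O)c1cc2ccccc2cn1)C(=O)OCc1ccccc1` differs from compound 2 in one place: sec-butyl in place of 2-carbamoylethyl on a saturated chain carbon bound to an amide-type nitrogen and a carbonyl carbon. Since sec-butyl, like isopropyl, carries no hydrogen-bond donors or acceptors, the change largely reverses that step, so a rise of similar size in this assay is expected, a number 16.1 percentage points higher from compound 2 to compound 3 (beyond the scatter). Compound 3 is therefore estimated at 28%, between 14% and 42%.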

Compound 3, a percentage reported as inhibition, in the whole organism at one dose (the size of the read-out at that dose, not a potency): 20.9%
Compound 3: middle estimate off by 7.1 percentage points, on the high side; low and high end bracket the measured number.
By their numbers in this assay, from the lowest: compounds 2, 3 and 1 (each within the scatter of the next, the first and the last beyond it).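

In this assay, sec-butyl cannot be told apart from 2-carbamoylethyl at this position (a number 9 percentage points higher from compound 2 to compound 3 (within the scatter)), nor from isopropyl (a number 8.8 percentage points lower from compound 1 to compound 3 (within the scatter)). The clear gap between isopropyl and 2-carbamoylethyl therefore does not extend to every chain without hydrogen-bond donors or acceptors, and methyl in place of hydrogen on the chain leaves no readable step. Nothing measured here explains these results. Going by these compounds, an amine or a carboxylic acid on this carbon remains open, as does a longer straight chain.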